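Pyrrolidinyl for butyl on the aromatic nitrogen

The compounds below may be only part of what the source reports. "The series", "measured", "known", "first", "only" and "open" are said of these compounds alone.

In a functional assay on HT-29 cells (Homo sapiens) for inhibition, read by luminescence and CellTiter-Glo, with a stated time of 24 h (on this read-out higher numbers stand for an effect only at larger amounts of compound and lower numbers for an effect already at smaller amounts), compound 1 `CCCCn1nc(C(=O)N[C@H]2COc3ccccc3N(C)C2=S)nc1Cc1ccccc1` gives 510 nM, the lowest of the two numbers obtained. Compound 2 `CC(C)CCn1nc(C(=O)N[C@H]2COc3ccccc3N(C)C2=S)nc1Cc1ccccc1` gives 3640 nM in this assay, and the step of a 7.1-fold higher number from compound 1 to compound 2 (0.85 log units; beyond the scatter) belongs to methyl in place of hydrogen on a saturated chain carbon bound to two saturated chain carbons. Compound 3 `CN1C(=S)[C@@H](NC(=O)c2nc(Cc3ccccc3)n(C3CCN(C(=O)OC(C)(C)C)C3)n2)COc2ccccc21` reaches only a limit of this assay, > 10000 nM (the limit of > 10000 nM in this assay, at which 1 of the 3 values shown sits). Hence the step of an at least 19-fold higher number from compound 1 to compound 3 (1.29 log units; beyond the scatter). Compound 4 `CN1C(=S)[C@@H](NC(=O)c2nc(Cc3ccccc3)n(C3CCNC3)n2)COc2ccccc21` carries the change (pyrrolidin-3-yl in place of butyl on an aromatic nitrogen), a five-membered non-aromatic ring with 1 hetero atom entering where the four-carbon chain leaves. Both measured enlargements on this aromatic nitrogen raised the number, so a rise beyond the scatter is expected for compound 4, estimated as a 7.8-fold higher number from compound 1 to compound 4 (0.89 log units; beyond the scatter). The expected value for compound 4 is 4000 nM, within 1000 nM to 20000 nM.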

Compound 4, half-maximal effective concentration: 1070 nM
Compound 4: the middle estimate sits 3.7-fold (0.57 log units) above what was measured; measured number inside the range.
By their numbers in this assay, from the lowest: compound 1; then compound 4; then compound 2. At a limit, above all of these: compound 3.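

Butyl keeps the lowest number at this aromatic nitrogen, and pyrrolidin-3-yl in its place gives a 2.1-fold higher number from compound 1 to compound 4 (0.32 log units; beyond the scatter). Against the branched chain the ring fares better, with a 3.4-fold lower number from compound 2 to compound 4 (0.53 log units; beyond the scatter), so a ring here need not cost as much as the added methyl did. Removing tert-butoxycarbonyl from the ring amine nitrogen gives an at least 9.3-fold lower number from compound 3 to compound 4 (0.97 log units; beyond the scatter), which is only a bound, since compound 3 stands at a limit: the limit of > 10000 nM in this assay, at which 1 of the 4 values shown sits.

Open, going by these compounds, is whether the ring or its nitrogen accounts for the lower number against isopentyl. Cyclopentyl, or a methyl on that ring nitrogen, would separate the two.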